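A Nitrophenyl Swap on the Triazole Benzyl Arm

The source may report more compounds than this note shows. Statements on the series, on what has been measured and on what is new or still open speak of the compounds shown alone.

Compound 3 `O=C(NCc1cn(Cc2ccc(F)c(Cl)c2)nn1)c1ccc([N+](=O)[O-])o1` carries a 3-chloro-4-fluorophenyl group on a saturated chain carbon bound to an aromatic nitrogen. In an ADME assay on MRC5 cells (Homo sapiens) for cytotoxicity (on this read-out lower numbers stand for stronger inhibition and higher numbers for weaker inhibition), compound 3 gives 254000 nM, the second highest of the three numbers measured. Compound 1 `COc1ccc(Cn2cc(CNC(=O)c3ccc([N+](=O)[O-])o3)nn2)cc1F` gives 324000 nM and compound 2 `COc1ccc(Cn2cc(CNC(=O)c3ccc([N+](=O)[O-])o3)nn2)cc1` gives 146000 nM. The steps at this position are a 1.3-fold lower number from compound 1 to compound 3 (0.11 log units; within the scatter) and a 1.7-fold higher number from compound 2 to compound 3 (0.24 log units; within the scatter), both within the scatter, while the step of a 2.2-fold lower number from compound 1 to compound 2 (0.35 log units; beyond the scatter) concerns a different place. Compound 4 `O=C(NCc1cn(Cc2cccc([N+](=O)[O-])c2)nn1)c1ccc([N+](=O)[O-])o1` differs from compound 3 by 3-nitrophenyl in place of 3-chloro-4-fluorophenyl on a saturated chain carbon bound to an aromatic nitrogen. Going by the values given here, no measured step introduces a 3-nitrophenyl group here, so the two aryl swaps seen are the only guide. Compound 4 is therefore expected to show no step beyond the scatter, a 1.0-fold lower number from compound 3 to compound 4 (0.01 log units; within the scatter). The estimated value of compound 4 is 250000 nM, with a range from 100000 nM to 550000 nM.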

Compound 4, half-maximal inhibitory concentration: 199000 nM
Compound 4: middle estimate off by 1.3-fold (0.10 log units), on the high side; measured number inside the range.
By their numbers in this assay, from the lowest: compounds 2, 4, 3 and 1 (each within the scatter of the next, the first and the last beyond it).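

Compound 4 places a 3-nitrophenyl group on the saturated chain carbon bound to an aromatic nitrogen, and in this assay all of its steps stay within the scatter (a 1.3-fold lower number from compound 3 to compound 4 (0.11 log units; within the scatter); a 1.4-fold higher number from compound 2 to compound 4 (0.13 log units; within the scatter); a 1.6-fold lower number from compound 1 to compound 4 (0.21 log units; within the scatter)). The nitro-bearing aryl group therefore does not separate from any of the three halogen or methoxy aryl groups at this position. No available evidence bears on this result.

Still open, going by these compounds, is whether an aminomethyl or carboxylic acid group on this aryl ring would give a step beyond the scatter. The same question stands for a longer saturated chain in place of the aryl ring.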